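Swapping an Aryl Ether for an Aryl Thioether

The compounds below may be only part of what the source reports. "The series", "measured", "known", "first", "only" and "open" are said of these compounds alone.

Compound 1, `Nc1cc(N)c2nc(-c3ccccc3)c(Oc3ccc(Cl)c(Cl)c3)nc2c1`: 5010 nM
Compound 2, `CCOC(=O)[C@H](CCC(=O)O)NC(=O)c1ccc(Sc2nc3cc(N)cc(N)c3nc2-c2ccccc2)cc1`: 11200 nM
Compound 3, `COc1cc(CNc2nc3cc(N)cc(N)c3nc2-c2ccccc2)cc(OC)c1OC`: 229 nM

Three compounds share one core and differ in the group hung from it. In a functional assay on MDA-MB-435 cells (Homo sapiens) for inhibition, read by sulforhodamine B assay, with a stated time of 48 h (a lower number here means a stronger inhibitor of growth, a higher number a weaker inhibitor of growth), compound 1 gives 5010 nM. Among the three measured numbers this leaves compound 1 second highest. Its nearest neighbour is compound 2, which gives 11200 nM, a gap that lies beyond the usual scatter of the measurement. Furthest away is compound 3, which gives 229 nM, the lowest number of the three and well beyond the scatter from compound 1. None of these pairs differ in only one place, so the three values cannot be split into single structural steps.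

Compound 4, `Nc1cc(N)c2nc(-c3ccccc3)c(Sc3ccc(Cl)c(Cl)c3)nc2c1`, has not yet been measured. It differs from compound 1 in a single place: (3,4-dichlorophenyl)sulfanyl in place of 3,4-dichlorophenoxy on an aromatic carbon. Compound 2 also carries a sulfur-linked group, but on a quite different aryl partner, so it gives no clean comparison. With nothing in the measured set to anchor the change, the step is expected to be modest, a 1.1-fold lower number from compound 1 to compound 4 (0.05 log units; within the scatter), and not clearly beyond the scatter in either direction. Compound 4 is therefore estimated at 4500 nM in this assay, within a range from 1500 nM to 13000 nM.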

Compound 4, concentration for 50% growth inhibition: 18200 nM
Compound 4: middle estimate off by 4.0-fold (0.61 log units), on the low side; the measured number lies above the stated range.
By their numbers in this assay, from the lowest: compound 3; then compound 1; then compounds 2 and 4 (each within the scatter of the next).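

Within the data shown here, the pair of compound 1 and compound 4 gives the first clean single change in this set. The two differ only in the atom that links the dichlorophenyl group to the shared core. In this assay that swap gives a 3.6-fold higher number from compound 1 to compound 4 (0.56 log units; beyond the scatter), so at this aromatic carbon, next to the ring nitrogen, sulfur cannot stand in for oxygen without weakening growth inhibition. The loss appears even though the leaving and entering groups have the same number of heavy atoms, hydrogen-bond donors and acceptors, and neither carries a net charge; no measurement shown here accounts for the difference.

Among these compounds, the single step leaves open whether replacing oxygen with sulfur has a similar effect when other aryl groups sit at this position, since compound 2 and compound 3 differ from compound 1 in more than one place. Also open, going by these compounds, is how a methylene link or an amine link carrying the same 3,4-dichlorophenyl group would compare with the ether of compound 1 and the thioether of compound 4.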